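A Third Methoxy on Compound 3

The source may report more compounds than this note shows. Statements on the series, on what has been measured and on what is new or still open speak of the compounds shown alone.

Among the measured compounds shown here, in a functional assay on MOLT-3 cells (Homo sapiens) for cytotoxicity, read by XTT assay, with a stated time of 48 h (on this read-out higher numbers stand for weaker inhibition and lower numbers for stronger inhibition), compound 3 `COc1cccc(/C=C/C(=O)c2cccc(-n3cc(COc4cc(=O)oc5ccccc45)nn3)c2)c1OC` gives 530 nM, the lowest of the three numbers measured so far. Compound 2 `COc1ccc(/C=C/C(=O)c2cccc(-n3cc(COc4cc(=O)oc5ccccc45)nn3)c2)cc1OC` gives 3910 nM and compound 1 `COc1ccc(/C=C/C(=O)c2cccc(-n3cc(COc4ccc5ccc(=O)oc5c4)nn3)c2)c(OC)c1OC` gives 3890 nM. These two values lie within the usual scatter of each other, and both lie beyond it from compound 3.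

Compound 4 `COc1ccc(/C=C/C(=O)c2cccc(-n3cc(COc4cc(=O)oc5ccccc45)nn3)c2)c(OC)c1OC` differs from compound 3 in one place: methoxy in place of hydrogen on an aromatic carbon. The new methoxy sits para to a large group, ortho to a methoxy group and meta to a methoxy group, turning 2,3-dimethoxyphenyl into 2,3,4-trimethoxyphenyl.

For the measured compounds named here, the one measured step that bears on this is a 7.4-fold lower number from compound 2 to compound 3 (0.87 log units; beyond the scatter), where 2,3-dimethoxyphenyl replaces 3,4-dimethoxyphenyl. Compound 4 holds every methoxy of compound 2 as well as every methoxy of compound 3, so it could fall anywhere between them. Going by the values given here, compound 1 carries the same 2,3,4-trimethoxyphenyl group on a different core and gives 3890 nM, which points the same way, though no measured step links it to compound 4.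

A move toward a higher number is therefore expected, of smaller size than the measured step. The expected change is a 3.0-fold higher number from compound 3 to compound 4 (0.48 log units; beyond the scatter). For compound 4 the estimated value is 1600 nM, with an expected range from 600 nM to 4000 nM.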

Compound 4, half-maximal inhibitory concentration: 1130 nM
The estimate for compound 4 lay 1.4-fold (0.15 log units) above the measured number; the measured number falls inside the stated range.
By their numbers in this assay, from the lowest: compound 3; then compound 4; then compounds 1 and 2 (each within the scatter of the next).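

The third methoxy does not act in one direction in this assay: turning 2,3-dimethoxyphenyl into 2,3,4-trimethoxyphenyl gives a 2.1-fold higher number from compound 3 to compound 4 (0.33 log units; beyond the scatter), whereas turning 3,4-dimethoxyphenyl into the same group gives a 3.5-fold lower number from compound 2 to compound 4 (0.54 log units; beyond the scatter). The earlier compounds shown here could not show this, since the effect of adding a methoxy to either dimethoxyphenyl group on this core had not been seen, and here its direction depends on which two methoxy groups are already present. Compound 4 also gives compound 1 its first direct partner, and with 2,3,4-trimethoxyphenyl held constant, exchanging the group on the oxygen gives a 3.4-fold lower number from compound 1 to compound 4 (0.54 log units; beyond the scatter), so that part of the molecule also moves the number, while no measurement at hand explains any of these shifts.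

The compounds shown leave open whether a hydroxyl, a fluorine or an ethoxy on the same aromatic carbon would track with methoxy. They also leave open whether 2,3-dimethoxyphenyl would give a lower number than 2,3,4-trimethoxyphenyl on the core of compound 1, as it does on the core of compound 4.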